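A few compounds are considered here, and "the series" means these few. Any claim that something is new, unique, unknown or untested is made for them only; others in the source may bear on it.

Measured so far:
- compound 1 `Cc1ccccc1/C=C1\CN(C(=S)NC(=O)c2ccccc2)C/C(=C\c2ccccc2C)C1=O`: < 10000 nM (a limit)
- compound 2 `Cc1ccc(/C=C2\CN(C(=S)NC(=O)c3ccccc3)C/C(=C\c3ccc(C)cc3)C2=O)cc1`: < 10000 nM (a limit)

In a functional assay on HCT-116 cells (Homo sapiens) for antiproliferative activity, read by MTT assay, with a stated time of 48 h (on this read-out lower numbers stand for stronger inhibition and higher numbers for weaker inhibition), compound 1 gives < 10000 nM, which is a limit and not a number. Compound 1 thus sits with compound 2 at the limit of < 10000 nM in this assay, at which 2 of the 2 values shown sit. Compound 3 `CCCCNC(=S)N1C/C(=C\c2ccccc2C)C(=O)/C(=C/c2ccccc2C)C1` has not been measured. It carries butyl in place of benzoyl on an amide-type nitrogen. For the measured compounds named here, no measured pair shows this change. In this assay no shift beyond the usual scatter is expected, so the estimated change is a step that the limit leaves unreadable from compound 1 to compound 3. For compound 3 the estimate is 4000 nM, with an expected range of 1000 nM to 15000 nM.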

Compound 3, half-maximal inhibitory concentration: < 10000 nM
Compound 3: only a limit was reported; the forecaster's own chance of this, stated with the estimate: 45%; the middle value lies beyond the limit too.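

No step can be read from compound 1 to compound 3, since both values are limits: the limit of < 10000 nM in this assay, at which 3 of the 3 values shown sit.

The compounds shown leave open whether butyl in place of benzoyl on an amide-type nitrogen changes activity at all.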